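Extending the aminoalkyl chain on the triazole of compound 1

The source may report more compounds than this note shows. Statements on the series, on what has been measured and on what is new or still open speak of the compounds shown alone.

Compound 1 `CN(C)CCn1cnnc1-c1cc(Oc2ccc(NC(=O)Nc3ccccc3C(F)(F)F)cc2F)ccn1` gives 5860 nM in a functional assay on HT-29 cells (Homo sapiens) for antiproliferative activity, read by MTT assay, with a stated time of 72 h (on this read-out lower numbers stand for stronger inhibition and higher numbers for weaker inhibition), the higher of the two numbers recorded there; its nearest neighbour, compound 2 `CN(C)CCn1cnnc1-c1cc(Oc2ccc(NC(=O)Nc3ccc(F)c(Cl)c3)cc2F)ccn1`, gives 720 nM, and that step, an 8.1-fold lower number from compound 1 to compound 2 (0.91 log units; beyond the scatter), changes only the aryl group on the urea. Compound 3 `CN(C)CCCn1cnnc1-c1cc(Oc2ccc(NC(=O)Nc3ccccc3C(F)(F)F)cc2F)ccn1` differs from compound 1 by (dimethylamino)methyl in place of dimethylamino on a saturated chain carbon, two bonds along the chain from an aromatic nitrogen, so that 2-(dimethylamino)ethyl becomes 3-(dimethylamino)propyl. For the measured compounds named here, no measured step touches this chain, so nothing here points to a shift beyond the scatter. Compound 3 is therefore expected near 5500 nM, within 2000 nM to 15000 nM, a step of a 1.1-fold lower number from compound 1 to compound 3 (0.03 log units; within the scatter).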

Compound 3, half-maximal inhibitory concentration: 3130 nM
Compound 3: middle estimate off by 1.8-fold (0.24 log units), on the high side; the range from low to high includes it.
By their numbers in this assay, from the lowest: compound 2; then compounds 3 and 1 (each within the scatter of the next).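

In this assay the move from 2-(dimethylamino)ethyl to 3-(dimethylamino)propyl gives a 1.9-fold lower number from compound 1 to compound 3 (0.27 log units; within the scatter) and so shows that this chain, untouched by the earlier step, takes this extension with no shift that stands clear of the scatter. For the compounds shown here, the only step beyond the scatter so far remains the one on the aryl group of the urea. No measurement shown offers a reason for this result.

From the compounds shown here alone, whether a 4-(dimethylamino)butyl chain or a morpholine at the chain end would move the number stays open. So does whether 3-(dimethylamino)propyl behaves alike with the 3-chloro-4-fluorophenyl urea of compound 2.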